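The source may report more compounds than this note shows. Statements on the series, on what has been measured and on what is new or still open speak of the compounds shown alone.

Measured compounds:
Compound 1 `CN(C)CCn1cnnc1-c1cc(Oc2ccc(NC(=O)N/N=C/c3ccc(O)cc3)cc2F)ccn1`: 820 nM
Compound 2 `CN(C)CCn1cnnc1-c1cc(Oc2ccc(NC(=O)N/N=C/c3cc(Br)c(O)c(Br)c3)cc2F)ccn1`: 4320 nM
Compound 3 `COc1ccc(/C=N/NC(=O)Nc2ccc(Oc3ccnc(-c4nncn4CCN(C)C)c3)c(F)c2)c(OC)c1OC`: 2020 nM

All three were tested in a functional assay on MKN-45 cells (Homo sapiens) for cytotoxicity, read by MTT assay, with a stated time of 72 h; a lower number here means a stronger inhibitor, a higher number a weaker inhibitor. Compound 2 stands at the highest number of the three: the step of a 5.3-fold higher number from compound 1 to compound 2 (0.72 log units; beyond the scatter) lies beyond the scatter, and so does a 2.1-fold lower number from compound 2 to compound 3 (0.33 log units; beyond the scatter), so compound 2 is the weakest of the three measured compounds in this assay.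

Compound 4 `COc1cc(/C=N/NC(=O)Nc2ccc(Oc3ccnc(-c4nncn4CCN(C)C)c3)c(F)c2)cc(OC)c1OC` differs from compound 2 in one place: 3,4,5-trimethoxyphenyl in place of 3,5-dibromo-4-hydroxyphenyl on a carbon with a double bond to nitrogen.

The step that bears most directly on this change is a 2.1-fold lower number from compound 2 to compound 3 (0.33 log units; beyond the scatter), where a trimethoxyphenyl also replaced the 3,5-dibromo-4-hydroxyphenyl, although in compound 3 the three methoxy groups sit as 2,3,4-trimethoxyphenyl rather than 3,4,5-trimethoxyphenyl. The related step of a 2.5-fold higher number from compound 1 to compound 3 (0.39 log units; beyond the scatter) shows that a trimethoxyphenyl gave a higher number than the unsubstituted 4-hydroxyphenyl of compound 1, yet still a lower one than compound 2. The account therefore expects compound 4 to sit close to compound 3, with a modest lowering from compound 2, roughly a 2.2-fold lower number from compound 2 to compound 4 (0.33 log units; beyond the scatter) in this assay. The estimate for compound 4 in this assay is 2000 nM, with a range from 800 nM to 5000 nM.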

Compound 4, half-maximal inhibitory concentration: 2900 nM
For compound 4 the middle estimate is 1.5-fold (0.16 log units) below the measured one, and the stated range covers the measured number.
By their numbers in this assay, from the lowest: compound 1; then compounds 3, 4 and 2 (each within the scatter of the next, the first and the last beyond it).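

Read in this assay this change gives a 1.5-fold lower number from compound 2 to compound 4 (0.17 log units; within the scatter) and so stays within the scatter, which means 3,4,5-trimethoxyphenyl on a carbon with a double bond to nitrogen cannot be told apart from 3,5-dibromo-4-hydroxyphenyl there, unlike the 2,3,4-trimethoxyphenyl of compound 3, whose step from compound 2 was beyond it. The arrangement of the three methoxy groups makes no readable difference in this assay, since the comparison gives a 1.4-fold higher number from compound 3 to compound 4 (0.16 log units; within the scatter) and also stays within the scatter, although only compound 3 is separated from compound 2. The comparison with the plain ring gives a 3.5-fold higher number from compound 1 to compound 4 (0.55 log units; beyond the scatter) and lies beyond the scatter, so the 4-hydroxyphenyl of compound 1 now keeps the lowest number against three substituted rings, those with bromine and those with methoxy groups.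

No supporting measurement bears on why these groups read as they do. Whether a 4-aminophenyl, a 4-carboxyphenyl or a single methoxy group at this place would match or better compound 1 stays open among the compounds shown.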